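Chloro to butyl on the six-membered carbon ring

The source may hold more compounds than are shown below. What is called first, only, known or untested is meant among the compounds shown, and "the series" means these compounds.

Compound 3 `CCCSc1nc(Nc2ccc(Cl)cc2)c2nc(Nc3ccccc3)sc2n1` gives 12500 nM in a functional assay on MGC-803 cells (Homo sapiens) for antiproliferative activity, read by MTT assay, with a stated time of 72 h (a lower number here means a stronger inhibitor, a higher number a weaker inhibitor), the lowest of the two numbers in hand; compound 1 `CCCSc1nc(Nc2ccccc2)c2nc(Nc3ccccc3)sc2n1` sits nearest at 24400 nM, and the gap a 2.0-fold lower number from compound 1 to compound 3 (0.29 log units; within the scatter) is within the scatter. Compound 2 `CCCSc1nc(NCc2ccco2)c2nc(Nc3ccccc3)sc2n1` reaches only the assay limit, > 64000 nM, as in the limit of > 64000 nM in this assay, at which 1 of the 3 values shown sits. Compound 4 `CCCCc1ccc(Nc2nc(SCCC)nc3sc(Nc4ccccc4)nc23)cc1` differs from compound 3 by butyl in place of chloro on an aromatic carbon. Going by the values given here, no measured step changes a carbon chain at that place: a 2.0-fold lower number from compound 1 to compound 3 (0.29 log units; within the scatter) was small, while an at least 2.6-fold higher number from compound 1 to compound 2 (0.41 log units; beyond the scatter) and an at least 5.1-fold lower number from compound 2 to compound 3 (0.70 log units; beyond the scatter) concern the whole nitrogen substituent rather than a group on its ring. The expected step of a 1.1-fold lower number from compound 3 to compound 4 (0.06 log units; within the scatter) is accordingly small, with no clear direction. Compound 4 is estimated at 11000 nM, range 4000 nM to 32000 nM.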

Compound 4, half-maximal inhibitory concentration: 17400 nM
Beside the measured number, compound 4's estimate is 1.6-fold (0.20 log units) below it; the range from low to high includes it.
By their numbers in this assay, from the lowest: compounds 3, 4 and 1 (each within the scatter of the next). At a limit, above all of these: compound 2.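

In this assay, butyl at this place on the ring is not separated from chloro, a 1.4-fold higher number from compound 3 to compound 4 (0.14 log units; within the scatter), or from hydrogen, a 1.4-fold lower number from compound 1 to compound 4 (0.15 log units; within the scatter), so this first carbon chain here leaves the number within the scatter of both. The whole nitrogen substituent still gives the only step beyond the scatter, an at least 3.6-fold lower number from compound 2 to compound 4 (0.56 log units; beyond the scatter), and this step is a bound rather than a size: the limit of > 64000 nM in this assay, at which 1 of the 4 values shown sits.

On these data alone, whether an amine, a carboxylic acid or a longer chain at this place would separate from chloro and butyl stays open.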